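A few compounds are considered here, and "the series" means these few. Any claim that something is new, unique, unknown or untested is made for them only; others in the source may bear on it.

Measured so far:
Compound 1 `Cc1cc(C)c(N2CCN(c3ncccn3)CC2)nn1`. In a functional assay on BV-2 cells (Mus musculus) for inhibition, read by ELISA, with a stated time of 16 h (a higher number here means a weaker inhibitor, a lower number a stronger inhibitor), compound 1 gives only a limit of the assay, > 100000 nM.
Compound 2 `Cc1cc(-c2ccsc2)nnc1N1CCN(c2ncccn2)CC1`. In this assay compound 2 gives 2400 nM.

Among the compounds with values here, compound 2 thus holds the only number in this assay; the other entry is a limit (the limit of > 100000 nM in this assay, at which 1 of the 2 values shown sits). Within the data shown here, the single measured step, an at least 41-fold lower number from compound 1 to compound 2 (1.61 log units; beyond the scatter), concerns a different group on an aromatic carbon and gives no direct read on compound 3 `Cc1cc(-c2cncnc2)nnc1N1CCN(c2ncccn2)CC1`, which carries pyrimidin-5-yl in place of thiophen-3-yl on an aromatic carbon. Among the measured compounds shown here, with no step comparing thiophen-3-yl against pyrimidin-5-yl, no change beyond the scatter is expected, though uncertainty is wide. Compound 3 is estimated at 4000 nM, within 1000 nM to 20000 nM. The expected step is a 1.7-fold higher number from compound 2 to compound 3 (0.22 log units; within the scatter).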

Compound 3, half-maximal inhibitory concentration: > 100000 nM
Compound 3 gave a limit, no number; the forecaster's own chance of this, stated with the estimate: 10%; at least 25-fold (1.39 log units) between middle value and limit.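

At this position, para to a large group, an aromatic ring alone does not secure activity: pyrimidin-5-yl in place of thiophen-3-yl gives an at least 41-fold higher number from compound 2 to compound 3 (1.61 log units; beyond the scatter) in this assay. Compound 1 and compound 3 both stand at a limit, not a number: the limit of > 100000 nM in this assay, at which 2 of the 3 values shown sit. The step from compound 1 to compound 3 cannot be read.

As far as these compounds go, whether a phenyl ring or a furan-3-yl ring here would keep a number in this assay remains open. Also open, from the compounds shown here alone, is how an amine or a carboxylic acid on the thiophen-3-yl ring would shift it.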